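This account rests on a few compounds, and the source may have more. Where it says the series, first, only, none or still open, it means among the compounds named here.

The study concerns three compounds built on one shared core. Compound 1 `Cc1ccc(OCC(=O)N(Cc2cccs2)C2CCCCC2)cc1` carries a cyclohexyl group on the amide-type nitrogen, and in an assay on HEK293 cells for agonist activity at transient receptor potential cation channel subfamily M member 8 (Homo sapiens), read by fluorescence and calcium flux, with a stated time of 15 min (a higher number here means that more compound is needed for the effect, a lower number that less compound is needed), compound 1 gives 40000 nM. Compound 2 `Cc1ccc(OCC(=O)N(CCO)Cc2cccs2)cc1` carries a 2-hydroxyethyl group there instead, and in this assay compound 2 gives 900 nM, the lowest of the two numbers obtained so far. For the measured compounds named here, the only step on record, a 44-fold lower number from compound 1 to compound 2 (1.65 log units; beyond the scatter), shows that replacing the cyclohexyl with the 2-hydroxyethyl brought a large change.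

Compound 3 `Cc1ccc(OCC(=O)N(Cc2cccs2)c2ccncc2)cc1` differs from compound 2 at the same position: pyridin-4-yl in place of 2-hydroxyethyl on an amide-type nitrogen. The step from compound 1 to compound 2 is the only one that bears on this change, and it is large; it shows that a ring on this nitrogen went with a much higher number than the short hydroxylated chain. Pyridin-4-yl is again a ring, though an aromatic one with an acceptor, so a higher number than compound 2 is expected, though not necessarily as high as that of compound 1. Compound 3 is therefore estimated to give 8000 nM in this assay, within a range from 1500 nM to 40000 nM, which means an expected step of an 8.9-fold higher number from compound 2 to compound 3 (0.95 log units; beyond the scatter).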

Compound 3, half-maximal effective concentration: 52 nM
The estimate for compound 3 lay 150-fold (2.19 log units) above the measured number, and the stated range ends above it.
By their numbers in this assay, from the lowest: compound 3; then compound 2; then compound 1.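

In this assay, pyridin-4-yl in place of 2-hydroxyethyl on the amide-type nitrogen brings a 17-fold lower number from compound 2 to compound 3 (1.24 log units; beyond the scatter) and so overturns the reading suggested by the first step: a ring at this position does not by itself go with a high number. The two ring-bearing compounds instead stand at opposite ends of the series, with a 770-fold lower number from compound 1 to compound 3 (2.89 log units; beyond the scatter) and compound 2 lying in the middle, so among these three compounds the kind of ring matters and not merely the presence of one. No measurement at hand accounts for the low number of compound 3 or for the wide gap between the cyclohexyl and pyridin-4-yl groups.

The compounds shown leave open whether the ring nitrogen of pyridin-4-yl plays any part, a question that a plain phenyl group on the same amide-type nitrogen, or a pyridin-3-yl group, would address directly. Also open, as far as these compounds go, is how a longer chain ending in a hydroxyl group or an amine would compare with the 2-hydroxyethyl group at this position.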